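Swapping the biaryl arm for a single chloro

The source may hold more compounds than are shown below. What is called first, only, known or untested is meant among the compounds shown, and "the series" means these compounds.

Measured so far:
compound 1 `COc1ccccc1-c1cccc(S(=O)(=O)N2CCC(N3CCC(C)CC3)CC2)c1`: 21 nM
compound 2 `COc1ccccc1-c1ccc(S(=O)(=O)N2CCC(N3CCC(C)CC3)CC2)cc1`: 26 nM
compound 3 `CC1CCCN(C2CCN(S(=O)(=O)c3ccc(OC(F)F)cc3)CC2)C1`: 105 nM

In a functional assay on DLD-1 cells (Homo sapiens) for antiproliferative activity, read by CellTiter-Glo, with a stated time of 72 h (on this read-out lower numbers stand for stronger inhibition and higher numbers for weaker inhibition), compound 1 gives the lowest of the three numbers. Compound 2 gives a number so close that the two cannot be told apart, while compound 3 gives a clearly higher number. Compound 4 `CC1CCN(C2CCN(S(=O)(=O)c3cccc(Cl)c3)CC2)CC1` has not yet been tested. It keeps the core of compound 1 but carries chloro in place of 2-methoxyphenyl on an aromatic carbon. Among the measured compounds shown here, a large group is thus replaced by a single atom, and the only guide is that compound 3, with a small substituent, gives 105 nM. The step of a 7.1-fold higher number from compound 1 to compound 4 (0.85 log units; beyond the scatter) is therefore expected to run toward weaker inhibition, beyond the scatter. Compound 4 is estimated at 150 nM, with a range from 40 nM to 600 nM.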

Compound 4, half-maximal inhibitory concentration: > 5000 nM
Compound 4 ended at the assay's limit; the forecaster's own chance of this, stated with the estimate: 5%; middle value at least 33-fold (1.52 log units) from the limit.
By their numbers in this assay, from the lowest: compounds 1 and 2 (each within the scatter of the next); then compound 3. At a limit, above all of these: compound 4.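

In this assay compound 4 gives > 5000 nM, which is a limit of the assay and not a number. Replacing 2-methoxyphenyl with chloro on this aromatic carbon gives an at least 230-fold higher number from compound 1 to compound 4 (2.37 log units; beyond the scatter), so at this position a single atom cannot stand in for the biaryl arm without inhibition leaving the measured range. The size of this step is therefore only a lower bound: the limit of > 5000 nM in this assay, at which 1 of the 4 values shown sits.

From the compounds shown here alone, what remains open is whether the loss comes from removing the aromatic ring, the oxygen or simply the bulk of the arm. A plain phenyl or a methoxy group on this carbon would help to separate these possibilities.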